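Bromo to Tert-Butoxy on the Benzothiazol-2-yl Core

This account rests on a few compounds, and the source may have more. Where it says the series, first, only, none or still open, it means among the compounds named here.

Compound 1, `Brc1ccc(-c2nnc(SCCCN3CCN(c4nc5ccccc5o4)CC3)o2)cc1`, in a functional assay on A-431 cells (Homo sapiens) for inhibition, read by MTT assay, with a stated time of 72 h; on this read-out lower numbers stand for stronger inhibition and higher numbers for weaker inhibition: compound 1 gives 57800 nM.
Compound 2, `CC(C)(C)Oc1ccc(-c2nnc(SCCCN3CCN(c4nc5ccccc5o4)CC3)o2)cc1`, in this assay: compound 2 gives 65800 nM.
Compound 3, `Brc1ccc(-c2nnc(SCCCN3CCN(c4nc5ccccc5s4)CC3)o2)cc1`, in this assay: compound 3 gives 51600 nM.

Compound 4, `CC(C)(C)Oc1ccc(-c2nnc(SCCCN3CCN(c4nc5ccccc5s4)CC3)o2)cc1`, is not yet measured. Compound 2 differs from compound 1 by tert-butoxy in place of bromo on an aromatic carbon, a change that gave a 1.1-fold higher number from compound 1 to compound 2 (0.06 log units; within the scatter). The two cores differ by 1,3-benzothiazol-2-yl in place of 1,3-benzoxazol-2-yl on an amine nitrogen in a ring, which gave a 1.1-fold lower number from compound 1 to compound 3 (0.05 log units; within the scatter). Compound 4 differs from compound 3 by tert-butoxy in place of bromo on an aromatic carbon, the same change at the same place. Since compound 3 gives 51600 nM and the earlier step was a 1.1-fold higher number from compound 1 to compound 2 (0.06 log units; within the scatter), a step of about a 1.1-fold higher number from compound 3 to compound 4 (0.04 log units; within the scatter) is expected here. Compound 4 is therefore estimated at 57000 nM, with a range from 30000 nM to 110000 nM.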

Compound 4, half-maximal inhibitory concentration: 67000 nM
Estimate against measurement, compound 4: 1.2-fold (0.07 log units) below; low and high end bracket the measured number.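

In this assay, tert-butoxy in place of bromo gave a 1.3-fold higher number from compound 3 to compound 4 (0.11 log units; within the scatter), which agrees with the same change on the core of compound 1: the same change on two cores in this assay, a 1.1-fold higher number (0.06 log units; within the scatter) from compound 1 to compound 2 and a 1.3-fold higher number (0.11 log units; within the scatter) from compound 3 to compound 4, 1.1-fold (0.06 log units) apart, within the scatter of two such steps. The exchange of cores gave a 1.0-fold higher number from compound 2 to compound 4 (0.01 log units; within the scatter), which likewise agrees with the earlier step: the same change on two cores in this assay, a 1.1-fold lower number (0.05 log units; within the scatter) from compound 1 to compound 3 and a 1.0-fold higher number (0.01 log units; within the scatter) from compound 2 to compound 4, 1.1-fold (0.06 log units) apart, within the scatter of two such steps. Among the compounds shown here, this shows that neither change moved the number beyond the scatter on either core, but it does not show that a real effect carries from one core to another, as no step here stands clear of the scatter.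

Going by these compounds, it remains open whether an amine or a carboxylic acid in place of bromo on that aromatic carbon would shift the number beyond the scatter. The same question stands for a longer chain on the sulfur.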